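Dichlorophenyl for fluorophenyl on the amine nitrogen: working notes

A few compounds are considered here, and "the series" means these few. Any claim that something is new, unique, unknown or untested is made for them only; others in the source may bear on it.

Measured so far in an assay on CHO cells for displacement of a labelled ligand from D(4) dopamine receptor (Homo sapiens), read by radioligand binding; on this read-out lower numbers stand for stronger inhibition and higher numbers for weaker inhibition:

- compound 1 `COc1ccccc1N1CCN(CCCNC(=O)NN(Cc2ccccc2F)c2ccc(F)cc2)CC1`: 3.6 nM
- compound 2 `COc1cccc(CN(NC(=O)NCCCN2CCN(c3ccccc3OC)CC2)c2ccc(F)cc2)c1`: 5.9 nM
- compound 3 `COc1ccccc1N1CCN(CCCNC(=O)NN(Cc2ccc(C#N)cc2)c2ccc(F)cc2)CC1`: 15 nM

Compound 3 gives the highest number of the three. Its nearest neighbour is compound 2, with the step of a 2.5-fold higher number from compound 2 to compound 3 (0.41 log units; beyond the scatter); compound 1 is furthest, with the step of a 4.2-fold higher number from compound 1 to compound 3 (0.62 log units; beyond the scatter). Between the other two the step of a 1.6-fold higher number from compound 1 to compound 2 (0.21 log units; within the scatter) stays inside the scatter. All three measured steps vary the aryl on the saturated chain carbon bound to the nitrogen on the aromatic ring, and the whole spread covered is modest.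

Compound 4 `COc1ccccc1N1CCN(CCCNC(=O)NN(Cc2ccc(C#N)cc2)c2ccc(Cl)cc2Cl)CC1` keeps the 4-cyanophenyl of compound 3 and differs by 2,4-dichlorophenyl in place of 4-fluorophenyl on an amine nitrogen. For the measured compounds named here, no measured step touches this amine-nitrogen aryl, so none bears directly on the change; the series so far only shows that nearby aryl swaps move this assay by modest amounts. No direction can be read from the data, and a step within the scatter or a modest one either way is expected, taken here as a 1.3-fold higher number from compound 3 to compound 4 (0.12 log units; within the scatter). For compound 4 the estimate is 20 nM, with a range from 5 nM to 80 nM.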

Compound 4, inhibition constant: 12 nM
Compound 4: the middle estimate sits 1.7-fold (0.22 log units) above what was measured, within the range that was stated.
By their numbers in this assay, from the lowest: compounds 1 and 2 (each within the scatter of the next); then compounds 4 and 3 (each within the scatter of the next).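

Compound 4 is the only compound shown that varies the aryl on the amine nitrogen, and with the 4-cyanophenyl held fixed, the swap to 2,4-dichlorophenyl gives (a 1.3-fold lower number from compound 3 to compound 4 (0.10 log units; within the scatter)) in this assay. Within the scatter, compounds 3 and 4 cannot be told apart, so at this position, in this one pair, two chlorines in place of one fluorine leave the number level, whereas the aryl swaps on the saturated chain carbon reached steps beyond the scatter. No measurement shown offers a reason for this result.

For the compounds shown here, open is whether the same holds with the 2-fluorophenyl or 3-methoxyphenyl on the saturated chain carbon, as the pair is seen only with 4-cyanophenyl. Also open, going by these compounds, is how a 4-chlorophenyl, a pyridyl or a simple methyl on the amine nitrogen would read.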